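This account rests on a few compounds, and the source may have more. Where it says the series, first, only, none or still open, it means among the compounds named here.

Compound 1 `CCCCCCCCCOC(=O)CCC(=O)N1CCN(CCCOc2cc3c(Nc4ccc(F)c(Cl)c4)ncnc3cc2OC)CC1`: 10.3%
Compound 2 `CCCCCCCCCCCCOC(=O)CCC(=O)N1CCN(CCCOc2cc3c(Nc4ccc(F)c(Cl)c4)ncnc3cc2OC)CC1`: 2%

In a functional assay on A549 cells (Homo sapiens) for cytotoxicity, read by MTT assay, with a stated time of 24 h, tested at 60 uM (on this read-out higher numbers stand for a weaker effect at the one concentration tested and lower numbers for a stronger effect), compound 2 gives 2%, which stands within the scatter of compound 1 at 10.3%; the step of a number 8.3 percentage points lower from compound 1 to compound 2 (within the scatter) is within the scatter, so the two read as equal. Compound 3 `CCCCCCCCCCCCCCCCCOC(=O)CCC(=O)N1CCN(CCCOc2cc3c(Nc4ccc(F)c(Cl)c4)ncnc3cc2OC)CC1` differs from compound 2 by pentyl in place of hydrogen on a saturated chain carbon, ten or more bonds along the chain from an oxygen next to a carbonyl group. Within the data shown here, the one measured step that bears on this, a number 8.3 percentage points lower from compound 1 to compound 2 (within the scatter), is a chain lengthening of the same kind and did not move beyond the scatter. The step of a number 1 percentage points higher from compound 2 to compound 3 (within the scatter) is therefore expected to stay within the scatter. Compound 3 is estimated at 3%, in the range 0% to 13%.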

Compound 3, a percentage reported as activity, at one concentration (the size of the read-out at that concentration, not a potency): 84.1%
Compound 3: the middle estimate sits 81.1 percentage points below what was measured; measured number above the stated range.
By their numbers in this assay, from the lowest: compounds 2 and 1 (each within the scatter of the next); then compound 3.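

Lengthening the chain at this position is not neutral in this assay: pentyl in place of hydrogen on a saturated chain carbon gives a large step (a number 82.1 percentage points higher from compound 2 to compound 3 (beyond the scatter)), and octyl in place of hydrogen gives another (a number 73.8 percentage points higher from compound 1 to compound 3 (beyond the scatter)). Compound 3, with the longest chain shown, is therefore the weakest of the three, while compound 1 and compound 2 remain within the scatter of each other. No measurement available here explains this abrupt change.

Chains of intermediate length leave open where between compound 2 and compound 3 the change sets in. From the compounds shown here alone, how an amine or a carboxylic acid on the chain would read also remains open.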